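This account rests on a few compounds, and the source may have more. Where it says the series, first, only, none or still open, it means among the compounds named here.

Compound 1, `Cc1cc(Oc2cc(N)nc(Nc3ccc(C#N)cc3)n2)ccc1-c1ccc(C#N)cc1`: 34300 nM in a toxicity assay on MT4 cells (Homo sapiens) for cytotoxicity, read by MTT assay; a higher number here means that more compound is tolerated, a lower number that less compound is tolerated
Compound 2, `Cc1cc(-c2cccc(Cl)c2)cc(C)c1Oc1cc(N)nc(Nc2ccc(C#N)cc2)n1`: 22300 nM in this assay
Compound 3, `Cc1ccccc1-c1cc(C)c(Oc2cc(N)nc(Nc3ccc(C#N)cc3)n2)c(C)c1`: 25600 nM in this assay

On these three numbers compound 3 stands second highest, though its neighbours are close: compound 2 is a little lower and compound 1 a little higher, and both gaps lie within the scatter. Within the data shown here, the one step measured between two compounds that differ in a single place, a 1.1-fold higher number from compound 2 to compound 3 (0.06 log units; within the scatter), swapped one aromatic ring for another on the same carbon and moved the number hardly at all.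

Compound 4, `Cc1cc(-c2ccc(C#N)c(F)c2)cc(C)c1Oc1cc(N)nc(Nc2ccc(C#N)cc2)n1`, changes compound 3 in that same place: 4-cyano-3-fluorophenyl in place of 2-methylphenyl on an aromatic carbon. The step from compound 2 to compound 3 bears on this, since it too changed the group on that carbon, and it stayed within the scatter. Among the measured compounds shown here, no measured compound carries a hydrogen-bond acceptor in the entering group at that place, so the evidence is thin, but it points to no step beyond the scatter; the expected step is a 1.0-fold lower number from compound 3 to compound 4 (0.01 log units; within the scatter). Compound 4 is therefore estimated at 25000 nM, within a range of 12000 nM to 50000 nM.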

Compound 4, half-maximal cytotoxic concentration: 5000 nM
For compound 4 the middle estimate is 5.0-fold (0.70 log units) above the measured one; measured number outside the range, below it.
By their numbers in this assay, from the lowest: compound 4; then compounds 2, 3 and 1 (each within the scatter of the next).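

The group on this aromatic carbon does matter in this assay: bringing in 4-cyano-3-fluorophenyl gives a 5.1-fold lower number from compound 3 to compound 4 (0.71 log units; beyond the scatter), and likewise a 4.5-fold lower number from compound 2 to compound 4 (0.65 log units; beyond the scatter), so less compound is tolerated. The earlier exchange of one aromatic ring for another, a 1.1-fold higher number from compound 2 to compound 3 (0.06 log units; within the scatter), had suggested that this place made little difference, but that holds only for the 3-chlorophenyl and 2-methylphenyl pair. Nothing available explains why the number falls with this group.

The nitrile and the fluorine enter together, so the compounds shown leave open whether either alone goes with the lower number. From the compounds shown here alone, how a simple 4-cyanophenyl or 3-fluorophenyl group, or a ring bearing an amine or a carboxylic acid, would behave at this place also remains open.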